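Three Phenyl Groups on One Ring Nitrogen

A few compounds are considered here, and "the series" means these few. Any claim that something is new, unique, unknown or untested is made for them only; others in the source may bear on it.

Three compounds have been tested in a functional assay on PC-12 cells (Rattus norvegicus) for cytotoxicity, read by MTT assay, with stated times of 2 h and 24 h, tested at 5 uM; a higher number here means a stronger effect of the compound at the concentration tested, a lower number a weaker effect:
Compound 1 `Oc1cc(C(F)(F)F)ccc1-c1nc(-c2ccccc2O)n(-c2ccc(F)cc2)n1` gives 86.7%.
Compound 2 `Oc1cc(C(F)(F)F)ccc1-c1nc(-c2ccccc2O)n(-c2ccccc2Cl)n1` gives 90.6%.
Compound 3 `COc1ccccc1-n1nc(-c2ccc(C(F)(F)F)cc2O)nc1-c1ccccc1O` gives 85.6%.

Among these three numbers compound 1 stands second highest, with compound 3 nearest and compound 2 furthest, and both gaps lie within the scatter. Compound 4 `Oc1cc(C(F)(F)F)ccc1-c1nc(-c2ccccc2O)n(-c2cccc(Cl)c2)n1` has not been measured. It differs from compound 1 in one place: 3-chlorophenyl in place of 4-fluorophenyl on an aromatic nitrogen. Two measured steps alter the same phenyl group and so bear on this change: a number 3.9 percentage points higher from compound 1 to compound 2 (within the scatter) and a number 1.1 percentage points lower from compound 1 to compound 3 (within the scatter). Neither moved the read-out beyond the scatter, so no step beyond the scatter is expected for compound 4 either. Compound 4 is therefore estimated at 88%, in a range from 80% to 95%, meaning an expected step of a number 1.3 percentage points higher from compound 1 to compound 4 (within the scatter).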

Compound 4, a percentage reported as activity, at one concentration (the size of the read-out at that concentration, not a potency): 92.7%
Beside the measured number, compound 4's estimate is 4.7 percentage points below it, and the stated range covers the measured number.
By their numbers in this assay, from the lowest: compounds 3, 1, 2 and 4 (each within the scatter of the next).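

The 3-chlorophenyl group puts a substituent at a new place on this phenyl group, yet the read-out in this assay stays within the scatter of all three earlier groups (a number 6 percentage points higher from compound 1 to compound 4 (within the scatter); a number 7.1 percentage points higher from compound 3 to compound 4 (within the scatter); a number 2.1 percentage points higher from compound 2 to compound 4 (within the scatter)). The position of the chlorine therefore makes no readable difference here, and the four compounds cannot be ranked. No measurement shown offers an explanation for this result.

Going by these compounds, every group tested at this nitrogen is a substituted phenyl, so a carboxylic acid or an amine on that ring, or a plain methyl in its place, remains open.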